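The compounds below may be only part of what the source reports. "The series", "measured", "known", "first", "only" and "open" are said of these compounds alone.

Values in a functional assay on HeLa cells (Homo sapiens) for cytotoxicity, read by WST assay, with a stated time of 48 h; on this read-out higher numbers stand for weaker inhibition and lower numbers for stronger inhibition:
- Compound 1 `COc1cc(C(c2ccc(O)c(OC)c2)[C@@H](C)[C@@H](C)CF)ccc1O`: 42000 nM.
- Compound 2 `COc1cc(C(c2ccc(O)c(OC)c2)[C@@H](C)[C@H](C)CO)ccc1O`: > 100000 nM, a limit of the assay and not a number.
- Compound 3 `COc1cc(C(c2ccc(O)c(OC)c2)[C@@H](C)[C@H](C)CF)ccc1O`: 37000 nM.

Compound 3 carries the lowest number in the set, but only narrowly: the step of a 1.1-fold lower number from compound 1 to compound 3 (0.06 log units; within the scatter) puts it level with compound 1. Against compound 2, the fluoro for hydroxy exchange gives an at least 2.7-fold lower number from compound 2 to compound 3 (0.43 log units; beyond the scatter), a step that rests on (the limit of > 100000 nM in this assay, at which 1 of the 3 values shown sits).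

Compound 4 `COc1cc(C(c2ccc(O)c(OC)c2)[C@H](C)[C@@H](C)CF)ccc1O` is the next case, and its relation to compound 3 is the two compounds have the same atoms and bonds and differ only in configuration as drawn: 2 of 2 stereo elements differ (all stereocentres are inverted: mirror images); a stereocentre at a saturated chain carbon is drawn R in compound 3 and S in compound 4; a stereocentre at a saturated chain carbon is drawn S in compound 3 and R in compound 4. The two are mirror images, so no group leaves or enters. The fluoro for hydroxy steps therefore do not apply here. The closest guide is a 1.1-fold lower number from compound 1 to compound 3 (0.06 log units; within the scatter), which reflects the fact that compounds 1 and 3 differ only in the configuration as drawn and changes one of the two stereocentres. Within the data shown here, no measured step inverts both at once, so that guide is incomplete. On this basis, no shift beyond the scatter is expected in this assay. The expected step is a 1.1-fold higher number from compound 3 to compound 4 (0.03 log units; within the scatter).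

For compound 4 the estimate is 40000 nM, with an expected range from 17000 nM to 90000 nM.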

Compound 4, half-maximal inhibitory concentration: 34000 nM
Beside the measured number, compound 4's estimate is 1.2-fold (0.07 log units) above it; the range from low to high includes it.
By their numbers in this assay, from the lowest: compounds 4, 3 and 1 (each within the scatter of the next). At a limit, above all of these: compound 2.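

Inverting both stereocentres at once, a change no earlier pair covered, gives a 1.1-fold lower number from compound 3 to compound 4 (0.04 log units; within the scatter) in this assay, and inverting one of them gives a 1.2-fold lower number from compound 1 to compound 4 (0.09 log units; within the scatter), so the three fluoro compounds are not separated by configuration at these saturated chain carbons, including the mirror-image pair, where the comparison concerns configuration alone: the fact that compounds 3 and 4 differ only in the configuration as drawn

Compound 2 stands at > 100000 nM, a limit of the assay and not a number.

Among these compounds, the exchange of 2-(hydroxymethyl)-1-methylpropyl for 2-(fluoromethyl)-1-methylpropyl gives an at least 2.9-fold lower number from compound 2 to compound 4 (0.46 log units; beyond the scatter), which is beyond the scatter, so the group at the chain end remains the only change in this set with a readable step, although the true size of that step is bounded on one side only.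

Open is whether the hydroxy group gives the same result in the other configurations, since the only hydroxy compound shown has the configuration of compound 3. Also open, going by these compounds, is how the number responds when an amine, a carboxylic acid or a longer chain stands at that chain end in place of the fluoromethyl group.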